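Indanyl ether in place of the bromophenyl ether

The compounds below may be only part of what the source reports. "The series", "measured", "known", "first", "only" and "open" are said of these compounds alone.

Measured so far:
compound 1 `Brc1ccccc1OC1CCN(c2ccc(-n3ccnc3)nn2)CC1` — 5 nM
compound 2 `N#Cc1ccccc1OC1CCN(c2ccc(-n3ccnc3)nn2)CC1` — 236 nM
compound 3 `CCc1ccccc1OC1CCN(c2ccc(-n3ccnc3)nn2)CC1` — 4 nM

In an assay on microsomes from liver for inhibition of acyl-CoA desaturase 1 (Rattus norvegicus) (on this read-out higher numbers stand for weaker inhibition and lower numbers for stronger inhibition), compound 1 gives 5 nM, the second highest of the three numbers. Its nearest neighbour is compound 3, where the change was a 1.3-fold lower number from compound 1 to compound 3 (0.10 log units; within the scatter); the furthest is compound 2, where the change was a 47-fold higher number from compound 1 to compound 2 (1.67 log units; beyond the scatter). Compound 3 and compound 2 lie far apart as well: a 59-fold lower number from compound 2 to compound 3 (1.77 log units; beyond the scatter).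

Compound 4 `c1cn(-c2ccc(N3CCC(Oc4ccc5c(c4)CCC5)CC3)nn2)cn1` differs from compound 1 in the aryl part of the ether: 2,3-dihydro-1H-inden-5-yl in place of 2-bromophenyl on an oxygen on a saturated carbon. For the measured compounds named here, no measured step covers this change directly. The bromine leaves without a replacement on that carbon, and a fused five-membered non-aromatic ring of carbon enters on the same six-membered aromatic ring. The steps at hand show that a carbon group in place of bromo leaves the number nearly unchanged, whereas cyano in place of bromo raises it strongly. Since the fused ring is a carbon group and no group like cyano enters, compound 4 is expected to stay in the lower part of the range, with perhaps a small rise for the lost bromo.

The estimate for compound 4 is 15 nM, between 4 nM and 60 nM, which means an expected step of a 3.0-fold higher number from compound 1 to compound 4 (0.48 log units; beyond the scatter).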

Compound 4, half-maximal inhibitory concentration: 62 nM
Compound 4: middle estimate off by 4.1-fold (0.62 log units), on the low side, outside the stated range (above it).
By their numbers in this assay, from the lowest: compounds 3 and 1 (each within the scatter of the next); then compound 4; then compound 2.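

In this assay the 2,3-dihydro-1H-inden-5-yl group sits well apart from the two aryl groups with low numbers, with a 12-fold higher number from compound 1 to compound 4 (1.09 log units; beyond the scatter) and a 16-fold higher number from compound 3 to compound 4 (1.19 log units; beyond the scatter) in this comparison. A carbon group in this part of the ether therefore does not by itself keep the number low, which the ethyl group alone could not reveal. The new group also stays clear of the 2-cyanophenyl group, with a 3.8-fold lower number from compound 2 to compound 4 (0.58 log units; beyond the scatter) as the step, so this position now gives three separate levels, and the step from compound 1 joins two changes, the loss of bromo and the entry of a fused five-membered non-aromatic ring, which these compounds do not separate.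

No evidence at hand gives a reason for these steps. Still open, on these data alone, is whether a plain phenyl group, with neither bromo nor the fused ring, would fall nearer compound 1 or compound 4, and where a methoxy group or an amine in place of bromo on the aromatic ring would fall.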